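Aminomethylphenol series: fluoro to trifluoromethyl on the distal ring

The source may report more compounds than this note shows. Statements on the series, on what has been measured and on what is new or still open speak of the compounds shown alone.

Measured so far:
compound 1 `Oc1ccccc1CNc1ccc(F)cc1` — "not active" (no number reported)
compound 2 `Oc1ccccc1CNc1ccc(N2CCCC2)cc1` — "not active" (no number reported)
compound 3 `Oc1ccccc1CNc1ccc(-c2ccc(F)cc2)cc1` — 3860 nM

In a functional assay on Jurkat cells (Homo sapiens) for activation, with a stated time of 24 h (a lower number here means that less compound is needed, a higher number that more compound is needed for the effect), compound 1 gives "not active" (no number reported) and compound 2 gives "not active" (no number reported); neither entry carries a number. Among the compounds with values here, compound 3 is the only member of the series with a number in this assay, giving 3860 nM. Within the data shown here, it therefore stands alone: nothing can be ranked against it, and no step between two measured compounds exists to calibrate what a change on the distal ring does.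

Compound 4 `Oc1ccccc1CNc1ccc(-c2ccc(C(F)(F)F)cc2)cc1` differs from compound 3 in one place: trifluoromethyl in place of fluoro on an aromatic carbon, on an aromatic carbon of a six-membered aromatic ring of carbon only. The fluoro that leaves and the trifluoromethyl that enters are both without ring, donors, acceptors or charge; the change is small in what is counted, apart from the three additional heavy atoms.

Among the measured compounds shown here, with no measured step to lean on, the expectation for compound 4 in this assay is a value close to that of compound 3, with no step in either direction clearly beyond the scatter, and compound 4 is estimated at 3500 nM (range 1000 nM to 12000 nM). The step this estimate implies is a 1.1-fold lower number from compound 3 to compound 4 (0.04 log units; within the scatter). A loss of activity, as seen for compound 1 and compound 2, cannot be excluded.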

Compound 4, half-maximal effective concentration: "not active" (no number reported)
Compound 4 has no reported number here, so the estimate cannot be set against anything.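

In this assay, within the data shown here, compound 4 gives "not active" (no number reported) and compound 3 gives 3860 nM with a number, so no step between the two can be read. The compounds shown leave open whether any group other than fluoro at this place gives a number in this assay at all. No measurement shown offers an explanation for this result.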